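Enantiomer pair in the chlorinated triazole series

A few compounds are considered here, and "the series" means these few. Any claim that something is new, unique, unknown or untested is made for them only; others in the source may bear on it.

Two compounds of the series have numbers in an ADME assay on RD cells (Homo sapiens) for cytotoxicity, read by MTT assay, with a stated time of 3 days (on this read-out higher numbers stand for lower toxicity in this test and lower numbers for higher toxicity in this test), so far. Compound 1, `CC[C@@H](CCn1cncn1)c1ccc(F)cc1`, gives 91.6 ug/mL. Compound 2, `CC[C@H](CCn1cncn1)c1ccc(Cl)cc1`, gives 57 ug/mL, and the two values sit within the usual scatter of each other, so no order between them is claimed. The next compound is compound 3, `CC[C@@H](CCn1cncn1)c1ccc(Cl)cc1`. Compared with compound 2, (the two compounds have the same atoms and bonds and differ only in configuration as drawn: 1 of 1 stereo elements differ; a stereocentre at a saturated chain carbon is drawn R in compound 2 and S in compound 3). Within the data shown here, no step between measured compounds is available to guide this change. In this assay the step of no change at the digits printed from compound 2 to compound 3 (within the scatter) is expected to stay within the scatter, in no particular direction. Compound 3 is therefore estimated at 57 ug/mL, with a range from 30 ug/mL to 110 ug/mL.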

Compound 3, half-maximal cytotoxic concentration: 55.3 ug/mL
For compound 3 the middle estimate is 1.0-fold (0.01 log units) above the measured one; low and high end bracket the measured number.
By their numbers in this assay, from the lowest: compounds 3, 2 and 1 (each within the scatter of the next).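

Inverting the stereocentre at the saturated chain carbon gives a 1.0-fold lower number from compound 2 to compound 3 (0.01 log units; within the scatter), so configuration at this carbon has no effect beyond the scatter in this assay. Chloro in place of fluoro on an aromatic carbon gives a 1.7-fold lower number from compound 1 to compound 3 (0.22 log units; within the scatter), which also stays within the scatter. The enantiomer comparison isolates a single variable: the fact that compounds 2 and 3 differ only in the configuration as drawn

Open, as far as these compounds go, is whether configuration would still leave the number within the scatter with a longer chain at the stereocentre. Also open, from the compounds shown here alone, is whether an amine in place of the halogen would move it beyond the scatter.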